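The compounds below may be only part of what the source reports. "The series", "measured", "known", "first", "only" and "open" are said of these compounds alone.

Three close relatives share one core and differ only in the aromatic group it carries: compound 1 (`O=C(NCCCCc1ccccc1)n1cc(-c2ccc(F)cc2)oc1=O`), compound 2 (`COc1cccc(-c2cn(C(=O)NCCCCc3ccccc3)c(=O)o2)c1`) and compound 3 (`COc1cc(-c2cn(C(=O)NCCCCc3ccccc3)c(=O)o2)ccc1F`). In a physicochemical assay for solubility, read by HPLC, in phosphate buffer, measured as kinetic solubility, with a stated time of 1 h, at pH 7.4, tested at 250 uM (a lower number here means a less soluble compound, a higher number a more soluble compound), compound 1 gives < 1000 nM as a limit of the assay and not a number. Compound 2 gives < 1000 nM which is again a limit. Compound 3 gives < 1000 nM which is likewise a limit, the same standing as its two relatives. The whole picture so far is the limit of < 1000 nM in this assay, at which 3 of the 3 values shown sit, and nothing finer.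

Going by the values given here, three measured steps bear on the next change: a step that the two limits leave unreadable from compound 1 to compound 2 and a step that the two limits leave unreadable from compound 1 to compound 3 and a step that the two limits leave unreadable from compound 2 to compound 3 all alter the aromatic group, yet none offers a size to carry over. Compound 4 (`O=C(NCCCCc1ccccc1)n1cc(-c2ccccn2)oc1=O`) brings a different kind of change, pyridin-2-yl in place of 4-fluoro-3-methoxyphenyl on an aromatic carbon and its entering ring holds a hetero atom, which no measured aromatic group here has.

The measured steps give no direction for this change, so any forecast is tentative. The expectation starts from compound 3 alone, whose reading of < 1000 nM is a limit. A modest rise is expected, an estimated at least 1.2-fold higher number from compound 3 to compound 4 (0.07 log units; that floor lies within the scatter) in this assay that could still end as a limit. For compound 4 the estimated solubility is 1200 nM within an expected range of 400 nM to 12000 nM in this estimate.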

Compound 4, solubility: < 1000 nM
Compound 4: a limit, no number; the forecaster's own chance of this, stated with the estimate: 50%; middle value at least 1.2-fold (0.07 log units) away from the limit.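

In this assay compound 4 gives < 1000 nM, which is a limit of the assay and not a number. No new step can be read, as the steps from compound 1, compound 2 and compound 3 to compound 4 all stay without a size. The compounds shown leave open how far these aromatic groups separate the four compounds, for the whole picture remains: the limit of < 1000 nM in this assay, at which 4 of the 4 values shown sit.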